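Working notes on a hydrazone series: the step to compound 4

The source may hold more compounds than are shown below. What is called first, only, known or untested is meant among the compounds shown, and "the series" means these compounds.

Measured so far:
- compound 1, `O=C(CSc1nnc(-c2ccncc2)o1)N/N=C/c1ccc(Br)cc1`, gives 19100 nM in a functional assay on MCF7 cells (Homo sapiens) for cytotoxicity, read by MTT assay, with a stated time of 48 h; on this read-out higher numbers stand for weaker inhibition and lower numbers for stronger inhibition
- compound 2, `Cc1ccc(/C=N/NC(=O)CSc2nnc(-c3ccncc3)o2)cc1`, gives 14700 nM in this assay
- compound 3, `O=C(CSc1nnc(-c2ccncc2)o1)N/N=C/c1cc(Br)ccc1O`, gives 7770 nM in this assay

Compound 3 stands at the lowest number of the three. Its distance from compound 1 is a 2.5-fold lower number from compound 1 to compound 3 (0.39 log units; beyond the scatter), while compound 2 sits closer, a 1.9-fold lower number from compound 2 to compound 3 (0.28 log units; within the scatter), so compound 3 is separated beyond the scatter from compound 1 only.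

The next compound, compound 4, `O=C(CSc1nnc(-c2ccncc2)o1)N/N=C/c1cc(Br)cc(Br)c1O`, differs from compound 3 by bromo in place of hydrogen on an aromatic carbon, placed ortho to the hydroxy group and meta to the existing bromo group.

Among the compounds with values here, no measured step swaps hydrogen for bromo on this ring. The nearest information is a 1.3-fold lower number from compound 1 to compound 2 (0.11 log units; within the scatter), where bromo and methyl on the other aryl ring gave numbers within the scatter, and a 2.5-fold lower number from compound 1 to compound 3 (0.39 log units; beyond the scatter), where the hydroxy-bearing ring brought a modest gain. A second bromo on that ring is therefore expected to move the number little, if at all, in this assay; the expected step is a 1.3-fold lower number from compound 3 to compound 4 (0.11 log units; within the scatter). Compound 4 is estimated at 6000 nM, with a range from 2500 nM to 15000 nM.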

Compound 4, half-maximal inhibitory concentration: 9010 nM
For compound 4 the middle estimate is 1.5-fold (0.18 log units) below the measured one, and the stated range covers the measured number.
By their numbers in this assay, from the lowest: compounds 3, 4, 2 and 1 (each within the scatter of the next, the first and the last beyond it).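

In this assay, this position ortho to a hydroxy group accepts bromo in place of hydrogen with no readable effect: a 1.2-fold higher number from compound 3 to compound 4 (0.06 log units; within the scatter). The 3,5-dibromo-2-hydroxyphenyl group keeps the profile of the 5-bromo-2-hydroxyphenyl group, with a 2.1-fold lower number from compound 1 to compound 4 (0.33 log units; beyond the scatter) against the 4-bromophenyl group and a 1.6-fold lower number from compound 2 to compound 4 (0.21 log units; within the scatter) against the 4-methylphenyl group, so the second bromo neither adds to nor removes the separation from compound 1. No evidence on hand bears on this result.

Going by these compounds, it remains open whether a different group at this position, such as an amine, a carboxylic acid or a methoxy group, would give a step beyond the scatter. On these data alone, the separate contribution of the hydroxy group also remains open, since each step from compound 1 exchanges the whole aryl group.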